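This account rests on a few compounds, and the source may have more. Where it says the series, first, only, none or still open, it means among the compounds named here.

Compound 1 `COc1cc(Oc2cccc(Nc3ccccc3)c2)cc(OC)c1CNCc1ccc(C)cc1`, compound 2 `COc1ccc(CCCNCc2c(OC)cc(Oc3cccc(Nc4ccccc4)c3)cc2OC)cc1` and compound 3 `CCN1CCN(Cc2c(OC)cc(Oc3cccc(Nc4ccccc4)c3)cc2OC)CC1` share one core. In a functional assay on SW-620 cells (Homo sapiens) for inhibition, read by MTT assay, with a stated time of 72 h (on this read-out lower numbers stand for stronger inhibition and higher numbers for weaker inhibition), compound 1 gives 11800 nM, while compound 2 gives 6400 nM, a step of a 1.8-fold lower number from compound 1 to compound 2 (0.27 log units; within the scatter). For compound 3 this assay reports only a limit, > 20000 nM, not a number. The steps toward it were an at least 1.6-fold higher number from compound 1 to compound 3 (0.22 log units; that floor lies within the scatter) and an at least 3.1-fold higher number from compound 2 to compound 3 (0.49 log units; beyond the scatter), with one of the three values resting at that limit (the limit of > 20000 nM in this assay, at which 1 of the 3 values shown sits). Compound 4 `COc1cc(Oc2cccc(Nc3ccccc3)c2)cc(OC)c1CNCc1ccc(Br)cc1` differs from compound 3 by (4-bromobenzyl)amino in place of 4-ethylpiperazin-1-yl on a saturated chain carbon bound to an aromatic carbon, which is a close relative of the change whose reverse was an at least 1.6-fold higher number from compound 1 to compound 3 (0.22 log units; that floor lies within the scatter). A step of about an at least 2.0-fold lower number from compound 3 to compound 4 (0.30 log units; that floor lies within the scatter) in this assay is therefore expected, back toward the numbers of compound 1. Compound 4 is estimated at 10000 nM, with a range of 4000 nM to 25000 nM.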

Compound 4, half-maximal inhibitory concentration: 11200 nM
For compound 4 the middle estimate is 1.1-fold (0.05 log units) below the measured one; low and high end bracket the measured number.
By their numbers in this assay, from the lowest: compounds 2, 4 and 1 (each within the scatter of the next). At a limit, above all of these: compound 3.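

In this assay, the benzylamine type of side chain again separates from the piperazine, now with bromo on the ring: an at least 1.7-fold lower number from compound 3 to compound 4 (0.25 log units; that floor lies within the scatter), but compound 3 carries a limit rather than a number, so this step is only a floor: the limit of > 20000 nM in this assay, at which 1 of the 4 values shown sits. Bromo in place of methyl on an aromatic carbon is a 1.1-fold lower number from compound 1 to compound 4 (0.02 log units; within the scatter), and 4-bromophenyl in place of 2-(4-methoxyphenyl)ethyl is a 1.8-fold higher number from compound 2 to compound 4 (0.24 log units; within the scatter). Compounds 1, 2 and 4 thus stay within the scatter of one another.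

Open, going by these compounds, is whether a morpholin-4-yl or piperidin-1-yl in place of 4-ethylpiperazin-1-yl would also sit at that limit. Also open, on these data alone, is whether chloro or methoxy in place of bromo would stay level with compound 4.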